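Compound 2 to compound 4: a fluoro step

The compounds below may be only part of what the source reports. "The series", "measured", "known", "first", "only" and "open" are said of these compounds alone.

Measured in a functional assay on BaF3 cells (Mus musculus) for inhibition, read by MTT assay, with a stated time of 3 days; on this read-out higher numbers stand for weaker inhibition of growth and lower numbers for stronger inhibition of growth
compound 1 `O=C(Nc1ccc(Br)cc1)Nc1ccc(Nc2ncnc3c2OCCN3)cc1` gives 10000 nM
compound 2 `CC(C)(C)c1cc(NC(=O)Nc2ccc(Nc3ncnc4c3OCCN4)cc2)no1` gives > 10000 nM as a limit
compound 3 `O=C(Nc1ccc(Nc2ncnc3c2OCCN3)cc1)Nc1cccs1` gives > 10000 nM as a limit

Compound 2 gives only the limit > 10000 nM and no number. The series as a whole is marked by the limit of > 10000 nM in this assay, at which 2 of the 3 values shown sit, and offers little to read beyond that.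

Compound 4 `CC(C)(C)c1cc(NC(=O)Nc2ccc(Nc3ncnc4c3OCCN4)cc2F)no1` carries fluoro in place of hydrogen on an aromatic carbon, ortho to a large group and meta to a large group.

Within the data shown here, no measured step involves this change. Going by these compounds, the steps of a number no lower from compound 1 to compound 2 (the limit leaves the size open) and a number no lower from compound 1 to compound 3 (the limit leaves the size open) replace the group on an amide-type nitrogen instead, and their size stays open. The step that the two limits leave unreadable from compound 2 to compound 3 cannot be read either. Among the measured compounds shown here, compound 1, the only one with a number, gives 10000 nM, so nothing measured points to a large move.

The expected step is a step that the limit leaves unreadable from compound 2 to compound 4 in this assay, with none expected beyond the scatter. For compound 4 the estimated value is 12000 nM, with an expected range from 5000 nM to 25000 nM, and a report of the limit alone is likely.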

Compound 4, concentration for 50% growth inhibition: > 10000 nM
Compound 4: a limit, no number; the forecaster's own chance of this, stated with the estimate: 80%; the middle value is on the limit's open side.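

No step can be read from compound 2 to compound 4, since each gives only a limit and no number: the limit of > 10000 nM in this assay, at which 3 of the 4 values shown sit.

Going by these compounds, whether fluoro in place of hydrogen on an aromatic carbon changes growth inhibition at all stays open with compound 2 and compound 4.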